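A few compounds are considered here, and "the series" means these few. Any claim that something is new, unique, unknown or untested is made for them only; others in the source may bear on it.

Measured compounds:
- compound 1, `CC(=O)OCc1ccc2oc(=O)c(C(=O)Oc3cccc(Cl)c3)cc2c1`: 6.17%
- compound 2, `CCCCC(=O)OCc1ccc2oc(=O)c(C(=O)Oc3cccc(Br)c3)cc2c1`: 32.3%

Both compounds were tested in a functional assay on HT-1080 cells (Homo sapiens), read by transwell migration, with a stated time of 24 h, tested at 10 uM; on this read-out higher numbers stand for a weaker effect at the one concentration tested and lower numbers for a stronger effect. Compound 1 gives 6.17% in this assay, while compound 2 gives 32.3%. Of the two numbers, compound 2 stands highest, and its nearest neighbour, compound 1, is lower by a margin beyond the usual scatter, so compound 2 shows the weaker effect of the pair. Compound 1 and compound 2 differ in more than one place, so no single change can be read from their values.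

Compound 3, `CC(C)C(=O)OCc1ccc2oc(=O)c(C(=O)Oc3cccc(Br)c3)cc2c1`, has not yet been measured. It is built from compound 2 by one change: isopropyl in place of butyl on a carbonyl carbon. Among the measured compounds shown here, no measured pair shows this change on its own, so its size cannot be taken from the numbers at hand. For the measured compounds named here, the only hint is that compound 1, carrying a shorter chain at this place, gives 6.17%. On that slim basis compound 3 is expected to give 25% in this assay, somewhere between 8% and 50%. The expected step of a number 7.3 percentage points lower from compound 2 to compound 3 (within the scatter) is small and lies within the scatter, pointing, if at all, towards a slightly stronger effect.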

Compound 3, a percentage reported as activity, at one concentration (the size of the read-out at that concentration, not a potency): 21.1%
Estimate against measurement, compound 3: 3.9 percentage points above; low and high end bracket the measured number.
By their numbers in this assay, from the lowest: compound 1; then compound 3; then compound 2.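

In this assay the change of butyl to isopropyl on a carbonyl carbon, with the rest of the molecule held the same, gives a number 11.2 percentage points lower from compound 2 to compound 3 (beyond the scatter) and so moves the read-out towards a stronger effect. Among the compounds shown here, this is the first direct sign that this place responds to the group it carries, even when the change is as small as going from 4 heavy atoms to 3 with no ring, donor, acceptor or charge involved on either side. Nothing at hand explains why the number moves, and no measurement of any property of these groups bears on it.

A single step cannot separate the shorter chain from its branched shape, and it leaves open how a straight propyl chain, a longer chain such as hexyl, or a group carrying an amine or a carboxylic acid would read at this place. From the compounds shown here alone, compound 1 differs from each of the other two compounds in more than one place, so the steps to it cannot be read, and the part played by the chlorine and bromine on the phenyl ester stays unknown.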